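The source may hold more compounds than are shown below. What is called first, only, known or untested is meant among the compounds shown, and "the series" means these compounds.

Measured so far:
- compound 1, `NCC1OCc2c1ccc(O)c2O`: 9800 nM
- compound 2, `CN(C)CC1OCc2c1ccc(O)c2O`: 1160 nM
- compound 3, `NCC1CCc2c1ccc(O)c2O`: 2250 nM

In an assay on isolated protein (Oryctolagus cuniculus) for binding affinity to Adrenergic receptor alpha-1 (Homo sapiens) (a higher number here means a weaker inhibitor, a lower number a stronger inhibitor), compound 3 gives 2250 nM, the second highest of the three numbers. Its nearest neighbour is compound 2, whose value lies within the usual scatter of that of compound 3; compound 1 sits further away, beyond the scatter, with the highest number of the set.

Compound 4, `CN(C)CC1CCc2c1ccc(O)c2O`, is not yet measured. It differs from compound 3 in one place: dimethylamino in place of amino on a saturated chain carbon bound to a saturated ring carbon. The same change has been seen once before, going from compound 1 to compound 2, where the core carries a ring oxygen instead of the carbon of compound 3: an 8.4-fold lower number from compound 1 to compound 2 (0.93 log units; beyond the scatter). Going by the values given here, that single step is the only guide here, and it points clearly downward, to a stronger inhibitor. Carrying it over, compound 4 is expected to show a lower number than compound 3 in this assay, a step of about a 7.5-fold lower number from compound 3 to compound 4 (0.88 log units; beyond the scatter). The estimate for compound 4 is therefore 300 nM, within a range of 100 nM to 900 nM.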

Compound 4, inhibition constant: 6900 nM
Estimate against measurement, compound 4: 23-fold (1.36 log units) below; the measured number lies above the stated range.
By their numbers in this assay, from the lowest: compounds 2 and 3 (each within the scatter of the next); then compounds 4 and 1 (each within the scatter of the next).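

In this assay, dimethylamino in place of amino on a saturated chain carbon bound to a saturated ring carbon turns out to have no fixed direction: it gives a 3.1-fold higher number from compound 3 to compound 4 (0.49 log units; beyond the scatter), whereas it earlier gave an 8.4-fold lower number from compound 1 to compound 2 (0.93 log units; beyond the scatter). The only other place where these pairs differ is the core, where a ring oxygen stands against a carbon. What this change does at this position therefore depends on the core that carries it, and one pair cannot be used as a rule for the other: the same change on two cores in this assay, an 8.4-fold lower number (0.93 log units; beyond the scatter) from compound 1 to compound 2 and a 3.1-fold higher number (0.49 log units; beyond the scatter) from compound 3 to compound 4, 26-fold (1.41 log units) apart, beyond the scatter of two such steps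

Two pairs cannot say whether the same split would appear on any further core. Methylamino at the same place on both cores would show whether the two series already part ways with a single methyl group on the amine.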